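A few compounds are considered here, and "the series" means these few. Any claim that something is new, unique, unknown or untested is made for them only; others in the source may bear on it.

Of the compounds shown here, three have been measured in an ADME assay on microsomes from liver (Homo sapiens) for metabolic stability, tested at 2.5 uM; a higher number here means faster removal of the compound, a lower number slower removal. Compound 1 `COc1cccc(-c2c(S(=O)(=O)c3cc(F)cc(F)c3)cnc3c(F)cccc23)c1` gives 2.76 mL/min. Compound 2 `COc1cccc(-c2c(S(=O)(=O)c3cc(Cl)cc(Cl)c3)cnc3c(F)cccc23)c1` gives 2.31 mL/min. Compound 3 `O=S(=O)(c1cc(Cl)cc(Cl)c1)c1cnc2c(F)cccc2c1-c1cccc(F)c1` gives 1.08 mL/min, the lowest of the three, and its gaps to the other two are beyond the scatter. Compound 2 and compound 1 differ in one place: 3,5-difluorophenyl in place of 3,5-dichlorophenyl on a sulfonyl sulfur. That change gives a 1.2-fold higher number from compound 2 to compound 1 (0.08 log units; within the scatter). Compound 2 and compound 3 differ in their cores: fluoro in place of methoxy on an aromatic carbon. That change gives a 2.1-fold lower number from compound 2 to compound 3 (0.33 log units; beyond the scatter).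

Compound 4 `O=S(=O)(c1cc(F)cc(F)c1)c1cnc2c(F)cccc2c1-c1cccc(F)c1` has not yet been measured in this assay. It differs from compound 3 in one place: 3,5-difluorophenyl in place of 3,5-dichlorophenyl on a sulfonyl sulfur. Within the data shown here, this is the same change as the one from compound 2 to compound 1, only made on the core of compound 3 rather than on the core of compound 2, and the place is described in the same words in both cases. For compound 4 the expected step is a 1.2-fold higher number from compound 3 to compound 4 (0.08 log units; within the scatter), resting on the single earlier case of this change, which gave a 1.2-fold higher number from compound 2 to compound 1 (0.08 log units; within the scatter), a step within the scatter, so little movement is expected here either. Compound 4 is accordingly estimated at 1.3 mL/min, with the likely range expected to run from 0.7 mL/min to 2.4 mL/min.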

Compound 4, intrinsic clearance in a liver preparation (reported as CLH), per the amount of preparation that the assay uses: 1.18 mL/min
Compound 4: the middle estimate sits 1.1-fold (0.04 log units) above what was measured, within the range that was stated.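

In this assay, 3,5-difluorophenyl in place of 3,5-dichlorophenyl on the sulfonyl sulfur gives a 1.1-fold higher number from compound 3 to compound 4 (0.04 log units; within the scatter), so this swap stays within the scatter on both cores and carries over from one to the other: the same change on two cores in this assay, a 1.2-fold higher number (0.08 log units; within the scatter) from compound 2 to compound 1 and a 1.1-fold higher number (0.04 log units; within the scatter) from compound 3 to compound 4, 1.1-fold (0.04 log units) apart, within the scatter of two such steps. Fluoro in place of methoxy on an aromatic carbon, now read with 3,5-difluorophenyl on the sulfonyl sulfur, gives a 2.3-fold lower number from compound 1 to compound 4 (0.37 log units; beyond the scatter), and this larger step also carries over, so in these four compounds the effect of each change looks the same whichever form the other place takes: the same change on two cores in this assay, a 2.1-fold lower number (0.33 log units; beyond the scatter) from compound 2 to compound 3 and a 2.3-fold lower number (0.37 log units; beyond the scatter) from compound 1 to compound 4, 1.1-fold (0.04 log units) apart, within the scatter of two such steps. Among these compounds, this agreement rests on only two cores for each change, so it does not show that either step would hold on a different core, and it does not explain why fluoro goes with slower removal than methoxy.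

The compounds shown leave open what an amine or a carboxylic acid would do in place of the halogens on the ring attached to the sulfonyl sulfur, and what a longer chain such as propoxy would do in place of methoxy. They also leave open whether the two steps would carry over in the same way once such groups are present.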